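The compounds below may be only part of what the source reports. "The series", "measured", "known", "first", "only" and "open" are said of these compounds alone.

Compound 1 `Nc1ccc(Oc2ccccc2-c2ccc(S(=O)(=O)NCCNC(=O)Nc3ccc(Cl)cc3)s2)cc1` - > 20000 nM (limit)
Compound 2 `O=S(=O)(NCCNC(=S)Nc1cccc(Cl)c1)c1ccc(-c2ccccc2OCc2ccccc2)s1` - 10200 nM
Compound 3 `Cc1cc(C)cc(NC(=O)NCCNS(=O)(=O)c2ccc(-c3ccccc3OCc3ccccc3)s2)c1` - > 20000 nM (limit)

In an ADME assay on HEK-293T cells (Homo sapiens) for cytotoxicity, read by CCK-8 assay, with a stated time of 48 h (a lower number here means a stronger inhibitor, a higher number a weaker inhibitor), compound 3 gives > 20000 nM, which is a limit and not a number. Compound 3 thus stands at the limit of > 20000 nM in this assay, at which 2 of the 3 values shown sit.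

Compound 4 `Cc1cc(C)cc(NC(=O)NCCNS(=O)(=O)c2ccc(-c3ccccc3Oc3ccc(N)cc3)s2)c1` differs from compound 3 by one change, 4-aminophenyl in place of benzyl on an oxygen on an aromatic ring. Among the compounds with values here, the one measured step, an at least 1.9-fold higher number from compound 2 to compound 3 (0.29 log units; that floor lies within the scatter), concerns a group on an amine nitrogen, not this oxygen, so it bears only loosely. Compound 1, which also carries 4-aminophenoxy, gives > 20000 nM, again a limit. No step beyond the scatter is therefore expected, and the estimated change is a step that the limit leaves unreadable from compound 3 to compound 4. For compound 4 the expected value is 25000 nM, with an estimated range of 12000 nM to 50000 nM, and another limit is likely.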

Compound 4, half-maximal inhibitory concentration: > 20000 nM
Compound 4: a limit, no number; the forecaster's own chance of this, stated with the estimate: 75%; the middle value is on the limit's open side.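

In this assay, within the data shown here, compound 4 gives > 20000 nM, a limit; compound 1 and compound 3 are limits too, so no step to compound 4 can be read. On these data alone, whether 4-aminophenyl in place of benzyl, or 3,5-dimethylphenyl in place of 4-chlorophenyl, changes the read-out at all stays open.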